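Chain Extension on the Acid Side Chain of Compound 1

A few compounds are considered here, and "the series" means these few. Any claim that something is new, unique, unknown or untested is made for them only; others in the source may bear on it.

Compound 1 `O=C(O)CCN1Cc2ccc(NC(=O)c3ccc(C4CCNCC4)cc3)cc2C1=O` gives 9600 nM in a functional assay on a cell-free system (Platelet, plasma, Homo sapiens) for inhibition (on this read-out lower numbers stand for stronger inhibition and higher numbers for weaker inhibition), the highest of the two numbers measured. Its nearest neighbour, compound 2 `O=C(O)CCN1Cc2ccc(NC(=O)c3ccc(N4CCNCC4)cc3)cc2C1=O`, gives 540 nM in this assay. This is a step of an 18-fold lower number from compound 1 to compound 2 (1.25 log units; beyond the scatter). Compound 3 `O=C(O)CCCN1Cc2ccc(NC(=O)c3ccc(C4CCNCC4)cc3)cc2C1=O` differs from compound 1 by carboxymethyl in place of carboxy on a saturated chain carbon, two bonds along the chain from an amide-type nitrogen in a ring. Among the compounds with values here, the only measured step concerns a different change, piperazin-1-yl in place of piperidin-4-yl, so no measured step bears on the longer chain. Compound 3 is therefore expected to sit close to compound 1, a step of a 1.3-fold higher number from compound 1 to compound 3 (0.10 log units; within the scatter), with wide uncertainty. The estimate for compound 3 is 12000 nM, between 3000 nM and 50000 nM.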

Compound 3, half-maximal inhibitory concentration: 410000 nM
Beside the measured number, compound 3's estimate is 34-fold (1.53 log units) below it; the measured number lies above the stated range.
By their numbers in this assay, from the lowest: compound 2; then compound 1; then compound 3.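

In this assay, the length of the acid side chain matters: going from 2-carboxyethyl to 3-carboxypropyl gives a 43-fold higher number from compound 1 to compound 3 (1.63 log units; beyond the scatter), which means weaker inhibition. Earlier, only the change from piperidin-4-yl to piperazin-1-yl had produced a large step, whereas this one arises at the chain alone, with the rest of compound 1 unchanged. No evidence at hand accounts for this loss. Still open, going by these compounds, is whether a shorter carboxymethyl chain would keep or improve inhibition. On these data alone, it is also open whether the longer chain would cost as much alongside piperazin-1-yl.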